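This account rests on a few compounds, and the source may have more. Where it says the series, first, only, none or still open, it means among the compounds named here.

Measured compounds:
- compound 1 `CN(C(=S)SCc1ccc(C(=O)Nc2ccccc2N)cc1)c1cccnc1` — 82.5%
- compound 2 `N#Cc1ccc(N2CCN(C(=S)SCc3ccc(C(=O)Nc4ccccc4N)cc3)CC2)cc1` — 37.6%

In a functional assay on MGC-803 cells (Homo sapiens) for antiproliferative activity, read by CCK-8 assay, with a stated time of 72 h, tested at 8 uM (on this read-out lower numbers stand for a weaker effect and higher numbers for a stronger effect at the one concentration tested), compound 1 gives 82.5% and stands highest of the two numbers; compound 2 gives 37.6%, which lies well beyond the scatter below it. Compound 3 `CC1CCN(C(=S)SCc2ccc(C(=O)Nc3ccccc3N)cc2)CC1` is unmeasured and differs from compound 1 in one place: 4-methylpiperidin-1-yl in place of methyl(pyridin-3-yl)amino on a thiocarbonyl carbon. Because compound 2 gives 37.6% with a different saturated nitrogen ring on the thiocarbonyl carbon, a step downward from compound 1 beyond the scatter is expected as a number 22.5 percentage points lower from compound 1 to compound 3 (beyond the scatter). Compound 3 is therefore estimated at 60%, within a range from 30% to 85%.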

Compound 3, a percentage reported as inhibition, at one concentration (the size of the read-out at that concentration, not a potency): 81.9%
Estimate against measurement, compound 3: 21.9 percentage points below; the range from low to high includes it.
By their numbers in this assay, from the lowest: compound 2; then compounds 3 and 1 (each within the scatter of the next).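

In this assay, 4-methylpiperidin-1-yl in place of methyl(pyridin-3-yl)amino on a thiocarbonyl carbon gives a number 0.6 percentage points lower from compound 1 to compound 3 (within the scatter), so this position tolerates a non-aromatic ring in place of the aromatic one. A saturated nitrogen ring here thus does not by itself go with a value as low as that of compound 2, at 37.6%. Nothing shown accounts for this result. The compounds shown leave open how a morpholine ring or a plain dimethylamino group on this thiocarbonyl carbon would read, and whether the methyl of compound 3 matters at all.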